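Swapping Phenoxy for Dimethylamino: An Expected Growth Inhibition

A few compounds are considered here, and "the series" means these few. Any claim that something is new, unique, unknown or untested is made for them only; others in the source may bear on it.

Of the compounds shown here, two sharing a core have been tested in a functional assay on HCT-15 cells (Homo sapiens) for inhibition, read by sulforhodamine B assay, with a stated time of 48 h; on this read-out higher numbers stand for weaker inhibition of growth and lower numbers for stronger inhibition of growth. Compound 1 `COc1cc(C)cc(-c2c(-c3ccnc(-c4ccc(C(C)=O)cc4)c3)cnn2CC#N)c1` is reported only as a limit, not as a number: in this assay compound 1 gives > 100000 nM. Going by the values given here, compound 2 `Cc1cc(O)cc(-c2nn(CC#N)cc2-c2ccnc(-c3ccc(Oc4ccccc4)cc3)c2)c1` is the one compound with an actual number; in this assay compound 2 gives 5380 nM. Among the compounds with values here, compound 2 therefore stands as the only measured value in the set. The other result is the limit of > 100000 nM in this assay, at which 1 of the 2 values shown sits.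

Compound 3 `Cc1cc(O)cc(-c2nn(CC#N)cc2-c2ccnc(-c3ccc(N(C)C)cc3)c2)c1` is not yet measured. It differs from compound 2 in one place: dimethylamino in place of phenoxy on an aromatic carbon, para to a large group. Within the data shown here, no measured pair in this set shows what such a swap does, so there is no direct guide to the size or direction of the change. The expectation is a modest weakening, with a real chance that the shift stays inside the ordinary scatter of repeated measurements. The estimated step is a 1.7-fold higher number from compound 2 to compound 3 (0.22 log units; within the scatter). Compound 3 is expected to give 9000 nM in this assay, with a likely range from 2500 nM to 40000 nM.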

Compound 3, concentration for total growth inhibition: 18200 nM
The estimate for compound 3 lay 2.0-fold (0.31 log units) below the measured number, and the stated range covers the measured number.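

In this assay, going by these compounds alone, putting dimethylamino in place of phenoxy on an aromatic carbon, para to a large group, gives a 3.4-fold higher number from compound 2 to compound 3 (0.53 log units; beyond the scatter), the first single change in this set whose effect can be read. A higher number here stands for weaker inhibition of growth, so this position does respond to the group it carries, and the step is beyond the usual scatter. Even so, losing the six-membered aromatic ring of phenoxy does not abolish the effect, as compound 3 still gives a real number of 18200 nM rather than a limit, and nothing measured here bears on the reason for the step.

Compound 1 gives > 100000 nM, which is a limit and not a number, and it differs from compound 2 in more than one place, so it cannot be read as a step at this position. As far as these compounds go, with only phenoxy and dimethylamino compared, it stays open whether the ring or the atom joined to the aromatic carbon matters more, a question that groups such as benzyloxy or morpholine at the same carbon could help to separate.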